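Removing the Chloro Group from Compound 2

This account rests on a few compounds, and the source may have more. Where it says the series, first, only, none or still open, it means among the compounds named here.

Of the compounds shown here, three sharing one core have been measured in a functional assay on M14 cells (Homo sapiens) for inhibition, read by sulforhodamine B assay, with a stated time of 48 h; on this read-out higher numbers stand for weaker inhibition of growth and lower numbers for stronger inhibition of growth. Compound 1 `N=C(N)c1ccc(-c2ccc(-c3cc(Cl)cc(Cl)c3)s2)cc1` gives 1540 nM. Compound 2 `N=C(N)c1ccc(-c2ccc(-c3ccc(Cl)cc3)s2)cc1F` gives 179 nM. Compound 3 `COc1cc(OC)cc(-c2ccc(-c3ccc(C(=N)N)c(F)c3)s2)c1` gives 184 nM. Among these three numbers compound 2 stands lowest; compound 3 lies within the usual scatter of it, so no order between the two can be drawn, while compound 1 lies beyond the scatter and is clearly weaker.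

Compound 4 `N=C(N)c1ccc(-c2ccc(-c3ccccc3)s2)cc1F` has not yet been measured in this assay. It differs from compound 2 in one place: hydrogen in place of chloro on an aromatic carbon. Within the data shown here, no measured pair in this set shows what this change alone does, so the expectation rests on the general behaviour of a halogen removal and on the spread of the three values. A modest loss of potency, somewhat beyond the scatter, is expected. Compound 4 is estimated to give 420 nM, in a range from 150 nM to 1200 nM. This estimate amounts to an expected step of a 2.3-fold higher number from compound 2 to compound 4 (0.37 log units; beyond the scatter).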

Compound 4, concentration for 50% growth inhibition: 2120 nM
The estimate for compound 4 lay 5.0-fold (0.70 log units) below the measured number; measured number above the stated range.
By their numbers in this assay, from the lowest: compounds 2 and 3 (each within the scatter of the next); then compounds 1 and 4 (each within the scatter of the next).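

In this assay, among these compounds, hydrogen in place of chloro on an aromatic carbon, para to a large group, gives a 12-fold higher number from compound 2 to compound 4 (1.07 log units; beyond the scatter), the first reading in this set of what this change does alone. The step is large, so in this pair the 4-chlorophenyl group cannot be exchanged for phenyl without a clear loss of growth inhibition, and this position is sensitive to that exchange. No measurement at hand accounts for the size of this loss.

On these data alone, whether another group at this position, such as fluoro, methyl, methoxy or an amine, would keep the growth inhibition seen with compound 2 remains open. As far as these compounds go, it is also open whether the same change would give a step of this size in a compound lacking the fluoro group of compound 2.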